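Swapping a Methoxy for a Methylpiperazine on a Shared Core

A few compounds are considered here, and "the series" means these few. Any claim that something is new, unique, unknown or untested is made for them only; others in the source may bear on it.

Two measured compounds share one core. Compound 1 `COc1cccc(-c2cc3[nH]nc(N)c3c(=O)[nH]2)c1` was tested in an assay on isolated protein for inhibition of ribosomal protein S6 kinase alpha-1 (Homo sapiens), read by mobility shift assay, tested at 30 uM (on this read-out lower numbers stand for less inhibition and higher numbers for more inhibition at the one concentration tested (going by the name of the read-out)), where compound 1 gives 20%. Compound 2 `COc1ccc(-c2cc3[nH]nc(N)c3c(=O)[nH]2)cc1` gives 7% in this assay, the lower of the two numbers, and its gap to compound 1 lies beyond the usual scatter. Compound 3 `CN1CCN(c2ccc(-c3cc4[nH]nc(N)c4c(=O)[nH]3)cc2)CC1` is not yet measured; it differs from compound 2 in one place: 4-methylpiperazin-1-yl in place of methoxy on an aromatic carbon. Going by the values given here, no measured pair shows this change, so the expected step in this assay is a number 8 percentage points higher from compound 2 to compound 3 (within the scatter), small and probably not beyond the scatter. Compound 3 is estimated at 15%, within 0% to 40%.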

Compound 3, a percentage reported as inhibition, at one concentration (the size of the read-out at that concentration, not a potency): 26%
Compound 3: middle estimate off by 11 percentage points, on the low side; low and high end bracket the measured number.
By their numbers in this assay, from the lowest: compound 2; then compounds 1 and 3 (each within the scatter of the next).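

At this place, on an aromatic carbon para to a large group, the small methoxy can be replaced by the much bulkier 4-methylpiperazin-1-yl without any loss of inhibition. In this assay, going by these compounds alone, this swap gives a number 19 percentage points higher from compound 2 to compound 3 (beyond the scatter) and is the first single change on the shared core whose effect can be read. Nothing available here bears on why the number rises.

As far as these compounds go, it remains open whether the gain follows the ring or its nitrogen atoms. A morpholine or an open-chain dimethylamino group at the same place could help tell these apart.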